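A few compounds are considered here, and "the series" means these few. Any claim that something is new, unique, unknown or untested is made for them only; others in the source may bear on it.

Measured so far:
compound 1 `Cc1noc(C)c1-c1cnc(N)c(Oc2ccc(C(=O)Nc3cc(Cl)ccn3)cc2)n1` – > 100000 nM
compound 2 `Cn1cc(-c2cnc(N)c(Oc3ccc(C(=O)Nc4cccc(Cl)c4)cc3)n2)cn1` – 21200 nM
compound 3 `Cn1cc(-c2cnc(N)c(Oc3ccc(C(=O)Nc4ccc(Cl)cn4)cc3)n2)cn1` – 24200 nM

In a functional assay on HepG2 cells (Homo sapiens) for inhibition, read by MTT assay, with a stated time of 72 h (a higher number here means a weaker inhibitor, a lower number a stronger inhibitor), compound 3 gives 24200 nM, the higher of the two numbers shown. The nearest value belongs to compound 2, with 21200 nM, and a 1.1-fold higher number from compound 2 to compound 3 (0.06 log units; within the scatter) sits within the scatter. The entry for compound 1 is a limit of this assay, not a number, as recorded in the limit of > 100000 nM in this assay, at which 1 of the 3 values shown sits.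

Compound 4 `Cn1cc(-c2cnc(N)c(Oc3ccc(C(=O)Nc4cc(Cl)ccn4)cc3)n2)cn1` has not been measured. It differs from compound 3 by 4-chloropyridin-2-yl in place of 5-chloropyridin-2-yl on an amide-type nitrogen. Among the measured compounds shown here, no measured step moves the chlorine around the pyridinyl ring in this way; the only measured step, a 1.1-fold higher number from compound 2 to compound 3 (0.06 log units; within the scatter), replaced the whole aryl group on the amide-type nitrogen and changed little. Compound 1 carries the 4-chloropyridin-2-yl group, but on a different core, so its limit does not stand as a step toward compound 4 and is noted only as a caution.

For the measured compounds named here, with no step of this kind measured, the expectation for compound 4 is a modest rise in number, a 1.9-fold higher number from compound 3 to compound 4 (0.27 log units; within the scatter), with a real chance that this assay returns only a limit. The estimate for compound 4 in this assay is 45000 nM, within a range of 12000 nM to 150000 nM.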

Compound 4, half-maximal inhibitory concentration: > 100000 nM
Compound 4: no number, only a limit; the forecaster's own chance of this, stated with the estimate: 35%; at least 2.2-fold (0.34 log units) between middle value and limit.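

In this assay the entry for compound 4 is a limit of the assay and not a number: the limit of > 100000 nM in this assay, at which 2 of the 4 values shown sit. On the shared core, the chlorine's place on the pyridinyl ring now shows up as a readable change on the amide-type nitrogen: 4-chloropyridin-2-yl in place of 5-chloropyridin-2-yl gives an at least 4.1-fold higher number from compound 3 to compound 4 (0.61 log units; beyond the scatter), while the earlier exchange of 3-chlorophenyl for 5-chloropyridin-2-yl gave a 1.1-fold higher number from compound 2 to compound 3 (0.06 log units; within the scatter). Set against 3-chlorophenyl, the 4-chloropyridin-2-yl group gives an at least 4.7-fold higher number from compound 2 to compound 4 (0.67 log units; beyond the scatter), so among these three compounds on the shared core only the 4-chloropyridin-2-yl group stands apart, and the other two groups cannot be told apart.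

The step between compound 1 and compound 4 joins two limits and cannot be read, so the exchange of 3,5-dimethyl-1,2-oxazol-4-yl for 1-methyl-1H-pyrazol-4-yl stays unresolved with this amide group. Also open, going by these compounds, is how a pyridin-2-yl group carrying an amine or a methoxy group in place of the chlorine would read in this assay.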